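The source may hold more compounds than are shown below. What is called first, only, known or untested is meant among the compounds shown, and "the series" means these compounds.

In an ADME assay on a cell-free system (plasma, Rattus norvegicus) for metabolic stability, read by LC-MS, with a stated time of 60 min, tested at 100 uM (a higher number here means that more of the compound is left, a lower number that less of the compound is left), compound 1 `Cc1c(OCCCCOc2ccc(C(=O)O)cc2F)ccc(C(=O)CC2CCCC2)c1O` gives 97%, compound 2 `COc1cc(C(=O)O)ccc1OCCCCOc1ccc(C(=O)CC(C)C)c(O)c1C` gives 99%, and compound 3 `Cc1c(OCCCCOc2ccc(C(=O)O)cc2F)ccc(C(=O)CC(C)C)c1O` gives 106%, so compound 3 stands within the scatter of both other compounds. Compound 4 `Cc1ccc(C(=O)O)cc1OCCCCOc1ccc(C(=O)CC(C)C)c(O)c1C` differs from compound 3 by one change on an oxygen on a saturated carbon: 5-carboxy-2-methylphenyl in place of 4-carboxy-2-fluorophenyl (5-carboxy-2-methylphenyl in place of 4-carboxy-2-fluorophenyl on an oxygen on a saturated carbon). Going by the values given here, no measured step makes this exact exchange, but two steps offer some guidance. With fluoro in place of methoxy on an aromatic carbon, the read-out shows a number 7 percentage points higher from compound 2 to compound 3 (within the scatter). With isopropyl in place of cyclopentyl on a saturated chain carbon bound to a carbonyl carbon, it shows a number 9 percentage points higher from compound 1 to compound 3 (within the scatter). With compound 2 at 99% and compound 1 at 97%, no step beyond the scatter is expected in this assay. The estimated step is a number 6 percentage points lower from compound 3 to compound 4 (within the scatter). For compound 4 the estimated value is 100%, with an expected range from 90% to 108%.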

Compound 4, percent of the compound remaining: 96%
Compound 4: the middle estimate sits 4 percentage points above what was measured; the range from low to high includes it.
By their numbers in this assay, from the lowest: compounds 4, 1, 2 and 3 (each within the scatter of the next).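

In this assay the read-out shows a number 10 percentage points lower from compound 3 to compound 4 (within the scatter), so this exchange on an oxygen on a saturated carbon stays within the scatter. The earlier steps shown here altered only one substituent on an aromatic carbon or the group on the saturated chain carbon, whereas here 5-carboxy-2-methylphenyl in place of 4-carboxy-2-fluorophenyl replaces the fluorine with carbon and also changes the number of the carboxy position in the group's name. The data give no reason for this reading, and no measurement bears on one.

The two differences within this exchange, the methyl for the fluoro and the new carboxy position, cannot be told apart from these compounds. From the compounds shown here alone, what an amine in place of the carboxylic acid, or a longer chain on that oxygen, would give in this read-out remains open.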